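The source may report more compounds than this note shows. Statements on the series, on what has been measured and on what is new or still open speak of the compounds shown alone.

Compound 1 `N#Cc1cc(F)cc(C(=O)Nc2cccc(F)c2)c1`: 2160 nM in an in vitro functional assay on HEK293-A cells for antagonist activity at metabotropic glutamate receptor 5 (Rattus norvegicus), read by calcium flux; a lower number here means a stronger inhibitor, a higher number a weaker inhibitor
Compound 2 `N#Cc1cc(F)cc(C(=O)Nc2ccc(F)cc2)c1`: > 10000 nM, a limit of this assay
Compound 3 `Cc1ccccc1NC(=O)c1cc(F)cc(C#N)c1`: > 30000 nM, a limit of this assay

Within the data shown here, of the three compounds measured so far, only compound 1 gives a number in this assay. Compound 2 sits at the limit (the limit of > 10000 nM in this assay, at which 1 of the 3 values shown sits), so its activity is known only as a bound, not as a value. Compound 3 sits at the limit (the limit of > 30000 nM in this assay, at which 1 of the 3 values shown sits). Among the measured compounds shown here, compound 2 therefore stands at the weak end of what this assay reports, and no step between it and another measured compound can be drawn.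

Compound 4 `COc1ccc(NC(=O)c2cc(F)cc(C#N)c2)cc1` differs from compound 2 in a single place: methoxy in place of fluoro on an aromatic carbon. No measured pair shows the same change, so there is no yardstick for it among these compounds. The step is expected to be small and without a clear direction, a step that the limit leaves unreadable from compound 2 to compound 4. Compound 4 is accordingly estimated at 15000 nM, with a range from 3000 nM to 60000 nM, and it may again be reported only as a limit.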

Compound 4, half-maximal inhibitory concentration: > 30000 nM
Compound 4 gave a limit, no number (the forecaster's own chance of this, stated with the estimate: 60%); middle value at least 2.0-fold (0.30 log units) from the limit.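

In this assay, among these compounds, compound 2 and compound 4 both stand only as limits, so no step between them can be read. The compounds shown leave open whether methoxy in place of fluoro on an aromatic carbon changes inhibition at all, and in which direction.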